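The compounds below may be only part of what the source reports. "The series", "measured", "known", "first", "only" and "open" are said of these compounds alone.

Measured in a functional assay on U-87MG ATCC cells for antiproliferative activity against U-87 MG (Homo sapiens), read by MTT assay, with a stated time of 48 h; on this read-out lower numbers stand for stronger inhibition and higher numbers for weaker inhibition:

Compound 1 `COc1ccc(-c2nc(SCC(=O)c3sc(-c4ccccc4)nc3C)[nH]c(=O)c2C#N)cc1`: 48400 nM
Compound 2 `COc1ccc(-c2nc(C)c(C(=O)CSc3nc(-c4ccc(OC)cc4)c(C#N)c(=O)[nH]3)s2)cc1`: 25300 nM
Compound 3 `COc1ccc(-c2nc(C)c(C(=O)CSc3nc(-c4cccc(OC)c4)c(C#N)c(=O)[nH]3)s2)cc1`: 15300 nM

Compound 3, at 15300 nM, lies within the scatter of compound 2 and clearly under compound 1, so it has the lowest number of the three only with respect to compound 1. The next analogue, compound 4 `COc1cccc(-c2nc(SCC(=O)c3sc(-c4ccccc4)nc3C)[nH]c(=O)c2C#N)c1`, has not yet been measured. It differs from compound 3 by hydrogen in place of methoxy on an aromatic carbon, which turns the 4-methoxyphenyl into phenyl, the group that compound 1 carries at this place.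

Within the data shown here, two measured steps bear on this change. The closest is the same exchange in the opposite direction, methoxy in place of hydrogen, which gave a 1.9-fold lower number from compound 1 to compound 2 (0.28 log units; within the scatter). The other, a 1.7-fold lower number from compound 2 to compound 3 (0.22 log units; within the scatter), concerns the second methoxyphenyl group, and it shows that compound 3 and compound 2 cannot be told apart in this assay. Reversing the first step suggests a rise of similar size, which would stay close to the scatter, so only a modest change is expected. The expected change is a 1.9-fold higher number from compound 3 to compound 4 (0.28 log units; within the scatter). For compound 4 the estimated value is 29000 nM, with an expected range from 14000 nM to 60000 nM.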

Compound 4, half-maximal inhibitory concentration: 59700 nM
Beside the measured number, compound 4's estimate is 2.1-fold (0.31 log units) below it, and the stated range covers the measured number.
By their numbers in this assay, from the lowest: compounds 3, 2, 1 and 4 (each within the scatter of the next, the first and the last beyond it).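

In this assay, removing the methoxy from the 4-methoxyphenyl, with the 3-methoxyphenyl group kept on the other side of the molecule, gave a 3.9-fold higher number from compound 3 to compound 4 (0.59 log units; beyond the scatter), so this exchange now shows a step that clears the scatter, which the earlier pair did not. The earlier and the new reading of the exchange point the same way and their sizes cannot be told apart: the same change on two cores in this assay, a 1.9-fold lower number (0.28 log units; within the scatter) from compound 1 to compound 2 and a 3.9-fold lower number (0.59 log units; beyond the scatter) from compound 4 to compound 3, 2.0-fold (0.31 log units) apart, within the scatter of two such steps

Moving the methoxy on the other aromatic ring, from the 4-methoxyphenyl to the 3-methoxyphenyl form, gave a 1.2-fold higher number from compound 1 to compound 4 (0.09 log units; within the scatter), and this change stays unresolved on both cores: the same change on two cores in this assay, a 1.7-fold lower number (0.22 log units; within the scatter) from compound 2 to compound 3 and a 1.2-fold higher number (0.09 log units; within the scatter) from compound 1 to compound 4, 2.0-fold (0.31 log units) apart, within the scatter of two such steps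

The compounds shown carry only hydrogen or methoxy on this aromatic carbon, so it remains open how a fluorine, a hydroxyl, an amine or a longer chain such as ethoxy would read there. As far as these compounds go, it also remains open whether the size of the methoxy step depends on which methoxyphenyl group the rest of the molecule carries.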